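A few compounds are considered here, and "the series" means these few. Any claim that something is new, unique, unknown or untested is made for them only; others in the source may bear on it.

Two compounds have been measured so far in a functional assay on DU-145 cells (Homo sapiens) for antiproliferative activity, read by propidium iodide staining, with a stated time of 96 h (on this read-out higher numbers stand for weaker inhibition and lower numbers for stronger inhibition), with these results:

Compound 1 `CC(O)(CSc1cccc(OC(F)(F)F)c1)C(=O)Nc1cccc(S(F)(F)(F)(F)F)c1` gives 25000 nM
Compound 2 `CC(O)(CS(=O)(=O)c1ccc(C(F)(F)F)cc1)C(=O)Nc1ccc(S(F)(F)(F)(F)F)cc1` gives 29300 nM

On these numbers, compound 2 stands level with compound 1, and the gap between them lies within the scatter of repeated measurements. For the measured compounds named here, the two compounds differ in more than one place, so no step from a single change has been measured yet.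

Compound 3 `CC(O)(CS(=O)(=O)c1ccc(OC(F)(F)F)cc1)C(=O)Nc1ccc(S(F)(F)(F)(F)F)cc1` keeps compound 2 intact except for one group: it has trifluoromethoxy in place of trifluoromethyl on an aromatic carbon, para to a large group (trifluoromethoxy in place of trifluoromethyl on an aromatic carbon). The data hold no direct measure of this exchange. Compound 1 carries trifluoromethoxy and gives 25000 nM, while compound 2 carries trifluoromethyl and gives 29300 nM, so the two values offer no sign of a large shift. No change beyond the scatter is therefore expected in this assay, and the estimated step is small (a 1.2-fold lower number from compound 2 to compound 3 (0.07 log units; within the scatter)). The estimated value for compound 3 is 25000 nM, with an expected range from 12000 nM to 50000 nM.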

Compound 3, half-maximal inhibitory concentration: 39300 nM
Estimate against measurement, compound 3: 1.6-fold (0.20 log units) below; the measured number falls inside the stated range.
By their numbers in this assay, from the lowest: compounds 1, 2 and 3 (each within the scatter of the next).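

In this assay, the exchange of trifluoromethyl for trifluoromethoxy on an aromatic carbon para to a large group now has a direct reading, with a 1.3-fold higher number from compound 2 to compound 3 (0.13 log units; within the scatter). Until now the two groups could be set side by side only through compounds that differ in more than one place, whereas this pair differs in that group alone. At this position, on this read-out and with the rest of compound 2 kept intact, the two groups cannot be told apart, and no information on any property of either group bears on this result.

The compounds shown carry only these two fluorinated groups at this position, so it remains open whether an amine, a carboxylic acid or a longer chain there would shift the number beyond the scatter. For the compounds shown here, also open is what a single change elsewhere would do, such as replacing the pentafluorosulfanyl group or the hydroxyl group of the shared core, since each step so far rests on one exchange at one position.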